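The compounds below may be only part of what the source reports. "The series", "measured", "known", "first", "only" and "open" are said of these compounds alone.

Measured compounds in an ADME assay on cells (Homo sapiens) for cytotoxicity; on this read-out lower numbers stand for higher toxicity in this test and higher numbers for lower toxicity in this test:
compound 1, `CCn1nnc(-c2ccc(OCCC(C)CCN3CCN(c4ccncc4)C3=O)cc2)n1`: > 12500 nM
compound 2, `CC(CCCN1CCN(c2ccncc2)C1=O)COc1ccc(-c2ccc(Cl)cc2)cc1`: > 25000 nM

Both values are limits of this assay rather than numbers. Compound 2 stands at the limit (the limit of > 25000 nM in this assay, at which 1 of the 2 values shown sits). Compound 1 stands at the limit (the limit of > 12500 nM in this assay, at which 1 of the 2 values shown sits). Compound 3, `CC(C)(CCCN1CCN(c2ccncc2)C1=O)COc1ccc(-c2ccc(Cl)cc2)cc1`, differs from compound 2 by methyl in place of hydrogen on a saturated chain carbon bound to three saturated chain carbons. Within the data shown here, no step between measured compounds is available to size this change. The step of a number no higher from compound 2 to compound 3 (the limit leaves the size open) is expected to be none beyond the scatter. Compound 3 is estimated at 25000 nM, with a range from 12500 nM to 50000 nM, and is expected most likely to be reported again only as a limit.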

Compound 3, half-maximal cytotoxic concentration: > 25000 nM
Compound 3 gave a limit, no number; the forecaster's own chance of this, stated with the estimate: 80%; the middle value lies on the limit itself.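

Compound 2 and compound 3 both stand as limits in this assay, and no step can be read between them for methyl in place of hydrogen. The compounds shown leave open whether that methyl changes the read-out at all, as none of the three has given a number.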